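Methoxy for nitro beside the phenol: thioxo-pyrimidine esters

The compounds below may be only part of what the source reports. "The series", "measured", "known", "first", "only" and "open" are said of these compounds alone.

Measured so far:
compound 1 `CCOC(=O)C1=C(C)N=C(S)NC1c1cccc([N+](=O)[O-])c1`, 95.4%
compound 2 `CCOC(=O)C1=C(C)NC(=S)NC1c1ccc(O)c([N+](=O)[O-])c1`, 57.1%

In a functional assay on aorta (Rattus norvegicus, strain Wistar) (on this read-out lower numbers stand for smaller maximal responses and higher numbers for larger maximal responses), compound 2 gives 57.1%, the lower of the two numbers; compound 1 gives 95.4%, a gap beyond the scatter. Going by the values given here, no step between compounds differing in one place is available, so nothing is known about how this read-out moves with any single change. Compound 3 `CCOC(=O)C1=C(C)NC(=S)NC1c1ccc(O)c(OC)c1` differs from compound 2 in one place: methoxy in place of nitro on an aromatic carbon. Among the compounds with values here, the step from compound 2 is expected to be moderate and upward, a number 12.9 percentage points higher from compound 2 to compound 3 (beyond the scatter), though this rests on no measured step. Compound 3 is estimated at 70%, within 45% to 95%.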

Compound 3, largest response reached (Emax), in percent of the reference or control that the assay uses: 78.3%
For compound 3 the middle estimate is 8.3 percentage points below the measured one; measured number inside the range.
By their numbers in this assay, from the lowest: compound 2; then compound 3; then compound 1.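

In this assay, methoxy in place of nitro on this aromatic carbon, ortho to a hydroxy group, gives a number 21.2 percentage points higher from compound 2 to compound 3 (beyond the scatter). Going by these compounds alone, this is the first single-place step, and it shows that the maximal response depends on the group at this position, with the larger number on the methoxy side. Nothing at hand bears on what lies behind the step.

As far as these compounds go, what an amine or a carboxylic acid on this carbon would give remains open. From the compounds shown here alone, it is also open whether a longer chain in place of methoxy would raise the number further.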